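This account rests on a few compounds, and the source may have more. Where it says the series, first, only, none or still open, it means among the compounds named here.

Measured so far: compound 2, `CCNc1ccc2c(c1)OC(N)=C(C#N)C2c1cc(Br)c(OC)c(OC)c1`, gives 14000000 nM in a functional assay on T47D cells (Homo sapiens) for activation; a lower number here means that less compound is needed, a higher number that more compound is needed for the effect; compound 1, `COc1cc(C2C(C#N)=C(N)Oc3c2ccc(C)c3C)cc(Br)c1OC`, gives 46000000 nM; compound 3, `CCNc1ccc2c(c1)OC(N)=C(C#N)C2c1cc(OC)c(OC)c(OC)c1`, gives 49000000 nM.

Compound 2 gives the lowest number of the three in this assay; compound 1 is the nearest, compound 3 the furthest. Compound 4, `COc1cc(C2C(C#N)=C(N)Oc3cc(O)ccc32)cc(Br)c1OC`, differs from compound 2 by hydroxy in place of ethylamino on an aromatic carbon. Within the data shown here, no measured step exchanges a group at this carbon. Among the measured compounds shown here, the only single-place step available, a 3.5-fold higher number from compound 2 to compound 3 (0.54 log units; beyond the scatter), concerns a different exchange and bears only loosely here. Compound 1, which lacks the ethylamino but also differs elsewhere, gives a higher number than compound 2 in this assay. A rise of modest size is expected, a 2.5-fold higher number from compound 2 to compound 4 (0.40 log units; beyond the scatter). Compound 4 is therefore estimated at 35000000 nM, within 10000000 nM to 120000000 nM.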

Compound 4, half-maximal effective concentration: 130000000 nM
Beside the measured number, compound 4's estimate is 3.7-fold (0.57 log units) below it; measured number above the stated range.
By their numbers in this assay, from the lowest: compound 2; then compounds 1 and 3 (each within the scatter of the next); then compound 4.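

In this assay, hydroxy in place of ethylamino on this aromatic carbon gives a 9.3-fold higher number from compound 2 to compound 4 (0.97 log units; beyond the scatter). Among these compounds, this is the first direct sign that the group on this carbon affects how much compound is needed, and here the group with fewer heavy atoms goes with the higher number. No measurement at hand explains this rise. Going by these compounds, with only these two groups compared at this carbon, it remains open whether a plain amine or a longer chain such as propylamino would stay close to compound 2. On these data alone, it is equally open whether methoxy would track with hydroxy.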